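A few compounds are considered here, and "the series" means these few. Any claim that something is new, unique, unknown or untested is made for them only; others in the source may bear on it.

Among the measured compounds shown here, in an ADME assay on a cell-free system (plasma, Homo sapiens) (a lower number here means a smaller unbound share, a higher number a larger unbound share of the compound), compound 2 `CCc1c(CCCC(=O)O)cccc1-c1nsc(-c2ccc(OC(C)C)c(C#N)c2)n1` gives 0.0021 and sits in the middle of the three numbers measured so far. Compound 1 `CCc1c(CN2CC(C(=O)O)C2)cccc1-c1nsc(-c2ccc(CC(C)C)c(C#N)c2)n1` stands higher with 0.0128 and compound 3 `CCc1c(CCCC(=O)O)cccc1-c1nsc(-c2ccc(OC(C)C)c(C(F)(F)F)c2)n1` lower with 0.00014 on the same scale. Compound 4 `CCc1c(CCCC(=O)O)cccc1-c1nsc(-c2ccc(CC(C)C)c(C#N)c2)n1` has isobutyl in place of isopropoxy on an aromatic carbon and is otherwise the same as compound 2. For the measured compounds named here, the only measured step of a 15-fold lower number from compound 2 to compound 3 (1.18 log units; beyond the scatter) is large but swaps another group, trifluoromethyl in place of cyano, so it gives no direction here. Compound 1 also carries isobutyl but differs elsewhere from compound 4, so it settles little. The expected change is a modest one toward a lower number, estimated as a 1.8-fold lower number from compound 2 to compound 4 (0.24 log units; within the scatter) in this assay overall. For compound 4 the estimate is 0.0012 with an expected range from 0.0004 to 0.0035 in this read-out.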

Compound 4, unbound fraction: 0.0003
Compound 4: middle estimate off by 4.0-fold (0.60 log units), on the high side, outside the stated range (below it).
By their numbers in this assay, from the lowest: compound 3; then compound 4; then compound 2; then compound 1.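

In this assay isobutyl in place of isopropoxy on this aromatic carbon, ortho to a cyano group, gives a 7.0-fold lower number from compound 2 to compound 4 (0.85 log units; beyond the scatter) and so removes the oxygen and its hydrogen-bond acceptor with a result beyond the scatter. With isobutyl held in place, 2-carboxyethyl in place of 3-carboxyazetidin-1-yl gives a 43-fold lower number from compound 1 to compound 4 (1.63 log units; beyond the scatter) as a large step on the saturated chain carbon. No evidence given here bears on the cause of either step. Going by these compounds, it remains open whether the isobutyl step holds with trifluoromethyl in place of cyano, and where an amine or a methoxy group on that aromatic carbon would stand.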